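Trading chlorophenyl for sulfamoylphenyl in compound 4

A few compounds are considered here, and "the series" means these few. Any claim that something is new, unique, unknown or untested is made for them only; others in the source may bear on it.

Of the compounds shown here, three have been measured in an in vitro functional assay on HEK285-7 cells for antagonist activity at prostaglandin D2 receptor 2 (Homo sapiens), read by BRET and beta-arrestin recruitment; a higher number here means a weaker inhibitor, a lower number a stronger inhibitor. Compound 1 `O=C(O)Cc1sc(C(c2ccccc2)c2ccc(F)cc2)nc1-c1ccc(Cl)cc1` gives 36 nM, compound 2 `O=C(O)Cc1sc(C(c2ccc(F)cc2)c2ccc(F)cc2)nc1-c1ccc(Cl)cc1` gives 180 nM, and compound 3 `O=C(O)Cc1sc(C(c2ccccc2)c2ccc(F)c(F)c2)nc1-c1ccc(F)cc1` gives 64 nM. Compound 2 therefore carries the highest number of the three, standing beyond the scatter above compound 3 and further still above compound 1. Among the compounds with values here, the single one-point step in the set, a 5.0-fold higher number from compound 1 to compound 2 (0.70 log units; beyond the scatter), is a modest weakening. Compound 4 `NS(=O)(=O)c1cccc(-c2nc(C(c3ccc(F)cc3)c3ccc(F)cc3)sc2CC(=O)O)c1` differs from compound 2 by 3-sulfamoylphenyl in place of 4-chlorophenyl on an aromatic carbon. Within the data shown here, no measured step bears directly on this change: the step from compound 1 to compound 2 concerns another part of the molecule, and compound 3 differs from compound 2 in more than one place, so its value shows only that a different group at this position is compatible with a number in the same broad range. The step this estimate implies, a 1.2-fold lower number from compound 2 to compound 4 (0.08 log units; within the scatter), is expected to lie within the scatter, with wide uncertainty. Compound 4 is accordingly estimated at 150 nM in this assay, within a range from 40 nM to 600 nM.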

Compound 4, half-maximal inhibitory concentration: 710 nM
Compound 4: the middle estimate sits 4.7-fold (0.68 log units) below what was measured; the whole stated range lies below it.
By their numbers in this assay, from the lowest: compounds 1 and 3 (each within the scatter of the next); then compound 2; then compound 4.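

Within the data shown here, exchanging 4-chlorophenyl for 3-sulfamoylphenyl, on the aromatic carbon next to the ring nitrogen, gives in this assay a 3.9-fold higher number from compound 2 to compound 4 (0.60 log units; beyond the scatter), the first direct reading of this position. The position is therefore not indifferent to the group it carries, yet compound 4 still gives a measurable number, so this exchange weakens inhibition without abolishing it. Nothing available here accounts for the size of this loss.

The exchange alters both the substituent on the phenyl ring and where it sits, and the compounds shown cannot separate these two changes. Also open, as far as these compounds go, is how an amine or a carboxylic acid would compare with the sulfamoyl group on that phenyl ring.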